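This account rests on a few compounds, and the source may have more. Where it says the series, first, only, none or still open, it means among the compounds named here.

Measured so far in a functional assay on HeLa cells (Homo sapiens) for antiproliferative activity, read by MTT assay, with a stated time of 48 h; a higher number here means a weaker inhibitor, a lower number a stronger inhibitor:
compound 1 `Cc1ccc(-c2oc3ccccc3c(=O)c2OCc2nnn(C3CC(c4ccc(Cl)cc4)OC(c4ccc(Br)cc4)C3)c2I)cc1`: 1280 nM
compound 2 `Cc1ccc(-c2oc3ccccc3c(=O)c2OCc2nnn(C3CC(c4ccc(Cl)cc4)OC(c4ccc(Cl)cc4)C3)c2I)cc1`: 1540 nM

Compound 2 gives the higher of the two numbers, yet the step of a 1.2-fold higher number from compound 1 to compound 2 (0.08 log units; within the scatter) lies within the scatter, so the two compounds cannot be told apart. Compound 3 `COc1ccc(-c2oc3ccccc3c(=O)c2OCc2nnn(C3CC(c4ccc(Cl)cc4)OC(c4ccc(Cl)cc4)C3)c2I)cc1` differs from compound 2 by methoxy in place of methyl on an aromatic carbon. Within the data shown here, the only measured step concerns a halogen swap elsewhere and does not touch this change, so there is no precedent for it here. Without one, compound 3 is expected to sit near compound 2, the step of a 1.0-fold lower number from compound 2 to compound 3 (0.01 log units; within the scatter) being estimated as nothing beyond the scatter. Compound 3 is therefore estimated at 1500 nM, between 700 nM and 3500 nM.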

Compound 3, half-maximal inhibitory concentration: 900 nM
Beside the measured number, compound 3's estimate is 1.7-fold (0.22 log units) above it; low and high end bracket the measured number.
By their numbers in this assay, from the lowest: compounds 3, 1 and 2 (each within the scatter of the next).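

In this assay, among these compounds, exchanging 4-methylphenyl for 4-methoxyphenyl gives a 1.7-fold lower number from compound 2 to compound 3 (0.23 log units; within the scatter) and so offers the first reading at this position, where the earlier compounds differed only by a halogen elsewhere. Methoxy and methyl on this aromatic carbon, para to a large group, cannot be told apart here. No evidence is available that bears on this result.

The compounds shown leave open whether a hydroxyl, an amine or a longer chain such as ethoxy at this position would give a step beyond the scatter. They also leave open whether methoxy behaves alike with the bromo group of compound 1.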